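From 4-fluorophenyl to 2-fluoro-4-methylphenyl on the shared core

This account rests on a few compounds, and the source may have more. Where it says the series, first, only, none or still open, it means among the compounds named here.

In an ADME assay on microsomes from liver (Homo sapiens) for metabolic stability (on this read-out lower numbers stand for slow clearance and higher numbers for fast clearance), compound 3 `C[C@H](NC(=O)Cn1nnc2ccccc2c1=O)c1ccc(F)cc1` gives 31 mL/min/kg as the highest number in this small series. Compound 2 `COc1ccc([C@H](C)NC(=O)Cn2nnc3ccccc3c2=O)cc1` is the nearest number at 13 mL/min/kg and sits beyond the scatter from it. Compound 1 `C[C@@H](NC(=O)Cn1nnc2ccccc2c1=O)c1ccccc1` gives < 9.9 mL/min/kg as a limit of the assay and not a number.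

Compound 4 `Cc1ccc([C@H](C)NC(=O)Cn2nnc3ccccc3c2=O)c(F)c1` has yet to be measured. It carries 2-fluoro-4-methylphenyl in place of 4-fluorophenyl on a saturated chain carbon bound to an amide-type nitrogen and a saturated chain carbon. Among the measured compounds shown here, the only measured step that bears on this change is a 2.4-fold higher number from compound 2 to compound 3 (0.38 log units; beyond the scatter) for fluoro in place of methoxy on an aromatic carbon, which is modest. For the measured compounds named here, it shows that this read-out can respond to a change on the aromatic ring, but no measured step covers the entering group. An estimated step of a 1.1-fold higher number from compound 3 to compound 4 (0.05 log units; within the scatter) is therefore expected to stay within the scatter. Compound 4 is estimated at 35 mL/min/kg with a range from 16 mL/min/kg to 70 mL/min/kg as the expected span.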

Compound 4, clearance: 28 mL/min/kg
Compound 4: middle estimate off by 1.3-fold (0.10 log units), on the high side, within the range that was stated.
By their numbers in this assay, from the lowest: compound 2; then compounds 4 and 3 (each within the scatter of the next). At a limit, below all of these: compound 1.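

On the saturated chain carbon bound to an amide-type nitrogen and a saturated chain carbon, 2-fluoro-4-methylphenyl in place of 4-fluorophenyl leaves this assay within the scatter, with a 1.1-fold lower number from compound 3 to compound 4 (0.04 log units; within the scatter). In place of 4-methoxyphenyl, the same group gives a 2.2-fold higher number from compound 2 to compound 4 (0.33 log units; beyond the scatter), so compound 4 joins compound 3 on the fast-clearance side of compound 2. Among the compounds with numbers, compound 2 now stands apart from two fluorine-bearing rings that lie within the scatter of each other.

As far as these compounds go, compound 1 gives a limit of the assay and not a number: the limit of < 9.9 mL/min/kg in this assay, at which 1 of the 4 values shown sits. How an amine or a carboxylic acid on this aromatic ring, or a longer chain in place of the methyl on the saturated chain carbon, would read in this assay remains open.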